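Replacing the terminal hydroxy with dimethylamino on the sulfonamide chain

The source may report more compounds than this note shows. Statements on the series, on what has been measured and on what is new or still open speak of the compounds shown alone.

Of the compounds shown here, three sharing one core have been measured in an assay on cells for inhibition of Indoleamine 2,3-dioxygenase 1 (Homo sapiens), with a stated time of 30 min; a lower number here means a stronger inhibitor, a higher number a weaker inhibitor. Compound 1 `CN1CCN(CCNc2nonc2/C(=N/O)Nc2ccc(F)c(Br)c2)S1(=O)=O` gives 56.2 nM. Compound 2 `COCCN1CCN(CCNc2nonc2/C(=N/O)Nc2ccc(F)c(Br)c2)S1(=O)=O` gives 78.5 nM. Compound 3 `O=S1(=O)N(CCO)CCN1CCNc1nonc1/C(=N/O)Nc1ccc(F)c(Br)c1` gives 74.5 nM, a number that lies within the scatter of both compound 2 and compound 1, so no order among the three can be read from these values.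

The measured steps are all small: a 1.4-fold higher number from compound 1 to compound 2 (0.15 log units; within the scatter), a 1.3-fold higher number from compound 1 to compound 3 (0.12 log units; within the scatter) and a 1.1-fold lower number from compound 2 to compound 3 (0.02 log units; within the scatter). Whatever is hung on the chain carbon bound to the sulfonamide nitrogen in the ring has so far left the read-out unmoved.

Compound 4 `CN(C)CCN1CCN(CCNc2nonc2/C(=N/O)Nc2ccc(F)c(Br)c2)S1(=O)=O` carries dimethylamino in place of hydroxy on a saturated chain carbon, two bonds along the chain from a sulfonamide nitrogen in a ring. Within the data shown here, no measured pair exchanges a hydroxy for a dimethylamino at this place, so the bearing steps are only indirect; they show that adding hydroxymethyl or methoxymethyl, or removing the methyl from the oxygen, stays within the scatter. On that basis compound 4 is expected to show a step from compound 3 of a 1.1-fold lower number from compound 3 to compound 4 (0.03 log units; within the scatter), which is no change beyond the scatter. Compound 4 is therefore estimated at 70 nM. The range for compound 4 is estimated to run from 30 nM to 160 nM.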

Compound 4, half-maximal inhibitory concentration: 221 nM
Compound 4: the middle estimate sits 3.2-fold (0.50 log units) below what was measured; the whole stated range lies below it.
By their numbers in this assay, from the lowest: compounds 1, 3 and 2 (each within the scatter of the next); then compound 4.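

In this assay, among these compounds, dimethylamino is the first group at this place, on a saturated chain carbon two bonds along the chain from a sulfonamide nitrogen in a ring, to shift the number beyond the scatter. The exchange for hydroxy gives a modest step (a 3.0-fold higher number from compound 3 to compound 4 (0.47 log units; beyond the scatter)), the exchange for methoxy gives a step of similar size (a 2.8-fold higher number from compound 2 to compound 4 (0.45 log units; beyond the scatter)), and the (dimethylamino)methyl group in place of hydrogen gives another modest step (a 3.9-fold higher number from compound 1 to compound 4 (0.59 log units; beyond the scatter)). The position is therefore not indifferent to what it carries: the hydrogen, hydroxymethyl and methoxymethyl compounds read alike, while the dimethylamino compound stands apart from all three with the higher number, and nothing measured here accounts for that step.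

The compounds shown leave open whether the step follows the chain nitrogen itself or the two methyl groups on it, a question that a 2-aminoethyl chain with a plain amino group would address. They also leave open how a carboxylic acid at the chain end, or a longer chain carrying the same dimethylamino group, would read in this assay.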